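Swapping the pyridine substituents on a thiazole acetic acid series

This account rests on a few compounds, and the source may have more. Where it says the series, first, only, none or still open, it means among the compounds named here.

Compounds measured so far:
compound 1, `O=C(O)Cc1sc(C(c2ccc(F)cc2)c2ccc(F)cc2)nc1-c1cc(F)cc(F)c1`, 35 nM
compound 2, `N#Cc1ccc(-c2nc(C(c3ccc(F)cc3)c3ccc(F)cc3)sc2CC(=O)O)cc1`, 150 nM
compound 3, `O=C(O)Cc1sc(C(c2ccc(F)cc2)c2ccc(F)cc2)nc1-c1cc(F)nc(F)c1`, 5.4 nM

The three share one core and differ only in the aromatic ring attached to it. In an in vitro assay on HEK385-7 cells for displacement of a labelled ligand from prostaglandin D2 receptor 2 (Homo sapiens) (a lower number here means a stronger inhibitor, a higher number a weaker inhibitor), compound 3 gives 5.4 nM, the lowest number of the three and the strongest binder here: the steps leading to it are a 6.5-fold lower number from compound 1 to compound 3 (0.81 log units; beyond the scatter) and a 28-fold lower number from compound 2 to compound 3 (1.44 log units; beyond the scatter), both beyond the scatter.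

Compound 4, `COc1cc(-c2nc(C(c3ccc(F)cc3)c3ccc(F)cc3)sc2CC(=O)O)ccn1`, has not been measured. It differs from compound 3 in one place: 2-methoxypyridin-4-yl in place of 2,6-difluoropyridin-4-yl on an aromatic carbon. Going by the values given here, no measured step shows exactly this exchange. What bears on it is that replacing the plain difluorophenyl of compound 1 by the difluoropyridyl ring gave a 6.5-fold lower number from compound 1 to compound 3 (0.81 log units; beyond the scatter), and that the cyanophenyl of compound 2 gave a 4.3-fold higher number from compound 1 to compound 2 (0.63 log units; beyond the scatter). Losing both fluorines while keeping the pyridine is therefore expected to give back part of the gain seen in compound 3, a modest rise in this assay rather than a large one. The step from compound 3 to compound 4 is estimated at a 3.7-fold higher number from compound 3 to compound 4 (0.57 log units; beyond the scatter), and compound 4 is estimated at 20 nM, within a range of 5 nM to 80 nM.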

Compound 4, half-maximal inhibitory concentration: 29 nM
Compound 4: the middle estimate sits 1.5-fold (0.16 log units) below what was measured, within the range that was stated.
By their numbers in this assay, from the lowest: compound 3; then compounds 4 and 1 (each within the scatter of the next); then compound 2.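

In this assay, a pyridine ring on this aromatic carbon of the shared core is not enough by itself to reach the low number of compound 3: with 2-methoxypyridin-4-yl in place of 2,6-difluoropyridin-4-yl, the result is a 5.4-fold higher number from compound 3 to compound 4 (0.73 log units; beyond the scatter). The methoxypyridine also brings no clear difference from the 3,5-difluorophenyl ring, since the comparison gives a 1.2-fold lower number from compound 1 to compound 4 (0.08 log units; within the scatter), so these two quite different rings cannot be told apart in this assay. It still does better than the 4-cyanophenyl ring, with a 5.2-fold lower number from compound 2 to compound 4 (0.71 log units; beyond the scatter), which leaves compound 2 with the highest number of the four and compound 3 with the lowest.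

Nothing measured here explains why these rings rank as they do. As far as these compounds go, because this single exchange removes the fluorines and adds the methoxy together, their separate shares remain open, as does whether a pyridine ring carrying a fluorine and a methoxy together, or an amine or a methyl group in place of the methoxy, would come closer to compound 3.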